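A few compounds are considered here, and "the series" means these few. Any claim that something is new, unique, unknown or untested is made for them only; others in the source may bear on it.

Among the compounds with values here, compound 2 `CN(C)CCNC(=O)CCC(=O)OCCCCCCSc1ccc([N+](=O)[O-])c2nonc12` gives 160 nM in an assay on isolated protein for inhibition of glutathione S-transferase Mu 2 (Homo sapiens), with a stated time of 10 min (on this read-out higher numbers stand for weaker inhibition and lower numbers for stronger inhibition), which places it at the higher of the two numbers measured so far; compound 1 `COc1ccc(NC(=O)CCC(=O)OCCCCCCSc2ccc([N+](=O)[O-])c3nonc23)cc1` gives 130 nM in this assay, and the gap between them is within the scatter. Compound 3 `O=C(CCC(=O)N1CCCCC1)OCCCCCCSc1ccc([N+](=O)[O-])c2nonc12` has not yet been measured. It differs from compound 2 by piperidin-1-yl in place of (2-(dimethylamino)ethyl)amino on a carbonyl carbon. Within the data shown here, the only measured step that bears on this change is a 1.2-fold higher number from compound 1 to compound 2 (0.09 log units; within the scatter), where a change at the same amide-type position left this assay unchanged beyond the scatter. On that basis no step beyond the scatter is expected from compound 2 to compound 3, in either direction, and the estimate for that step is a 1.1-fold higher number from compound 2 to compound 3 (0.03 log units; within the scatter). Compound 3 is therefore expected to give about 170 nM in this assay, with a range from 60 nM to 480 nM.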

Compound 3, half-maximal inhibitory concentration: 110 nM
Estimate against measurement, compound 3: 1.5-fold (0.19 log units) above; the measured number falls inside the stated range.
By their numbers in this assay, from the lowest: compounds 3, 1 and 2 (each within the scatter of the next).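

In this assay, piperidin-1-yl brings a six-membered non-aromatic ring and no hydrogen-bond donor to the carbonyl carbon, where (2-(dimethylamino)ethyl)amino counts one donor, yet the result is only a 1.5-fold lower number from compound 2 to compound 3 (0.16 log units; within the scatter). Set against the aromatic group, the same position gives a 1.2-fold lower number from compound 1 to compound 3 (0.07 log units; within the scatter), so all three groups now shown at this carbonyl carbon, open-chain, aromatic and ring-closed, lie within the scatter of one another, and the amide hydrogen lost in compound 3 is not needed to hold the number in this range. Nothing measured here accounts for this flat picture.

Going by these compounds, it remains open whether a carboxylic acid or a primary amine on this carbonyl carbon would move the number beyond the scatter. On these data alone, it is also open whether a longer chain in place of the hexyl-length linker of the shared core would matter more than this position does.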